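This account rests on a few compounds, and the source may have more. Where it says the series, first, only, none or still open, it means among the compounds named here.

Measured so far:
- Compound 1 `COc1cc(-c2ccnc3cc(-c4cn(C)c5ccccc45)nn23)cc(OC)c1OC`: 1340 nM
- Compound 2 `COc1cc(-c2ccnc3cc(-c4cccc(C)c4)nn23)cc(OC)c1OC`: 5730 nM

In a functional assay on A549 cells (Homo sapiens) for inhibition, read by CCK-8 assay, with a stated time of 48 h (a lower number here means a stronger inhibitor, a higher number a weaker inhibitor), compound 2 gives the higher of the two numbers, 5730 nM, making it the weaker inhibitor of the pair. Compound 3 `COc1cc(-c2ccnc3cc(-c4ccc5ccn(C)c5c4)nn23)cc(OC)c1OC` changes one group of compound 2: 1-methyl-1H-indol-6-yl in place of 3-methylphenyl on an aromatic carbon. Among the compounds with values here, the one measured step that bears on this is a 4.3-fold higher number from compound 1 to compound 2 (0.63 log units; beyond the scatter), a modest loss on going to 3-methylphenyl from 1-methyl-1H-indol-3-yl. Within the data shown here, compound 3 also replaces 3-methylphenyl with a 1-methyl-1H-indolyl group, but one attached differently, and no measurement yet covers that attachment. A similar or somewhat smaller move toward a lower number therefore seems likely, and the expected step is a 2.5-fold lower number from compound 2 to compound 3 (0.40 log units; beyond the scatter). For compound 3 the estimated value is 2300 nM, with an expected range of 800 nM to 6500 nM.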

Compound 3, half-maximal inhibitory concentration: 829 nM
For compound 3 the middle estimate is 2.8-fold (0.44 log units) above the measured one; low and high end bracket the measured number.
By their numbers in this assay, from the lowest: compounds 3 and 1 (each within the scatter of the next); then compound 2.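

Replacing 3-methylphenyl with 1-methyl-1H-indol-6-yl brings a 6.9-fold lower number from compound 2 to compound 3 (0.84 log units; beyond the scatter) in this assay and shows that a second way of attaching the methylindole also outperforms 3-methylphenyl at this position. The two attachments stand at a 1.6-fold lower number from compound 1 to compound 3 (0.21 log units; within the scatter) and so cannot be told apart here. Nothing available explains why either methylindole gives the lower number. Still open is how an amine or a morpholine would fare at this position, and whether the indole nitrogen needs its methyl, which both indole compounds shown carry.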